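Thiazolyl for hydroxyphenyl on the piperidine-bearing carbon of compound 2

The source may report more compounds than this note shows. Statements on the series, on what has been measured and on what is new or still open speak of the compounds shown alone.

Compound 2 `Cc1cccc(NC(=O)CN2CCC(c3ccc(O)cc3)CC2)c1` gives 60% in a functional assay on HEK293 cells for agonist activity at D(4) dopamine receptor (Homo sapiens), read by FLIPR (on this read-out higher numbers stand for larger maximal responses and lower numbers for smaller maximal responses), the second highest of the three numbers measured. Compound 1 `Cc1cccc(NC(=O)CN2CCC(c3ccccc3C#N)CC2)c1` gives 71%, and the step of a number 11 percentage points lower from compound 1 to compound 2 (beyond the scatter) lies beyond the scatter. Compound 3 `CSc1cccc(NC(=O)CN2CCC(c3cccc[n+]3[O-])CC2)c1` gives 56%, a number within the scatter of compound 2. Compound 4 `Cc1cccc(NC(=O)CN2CCC(c3nccs3)CC2)c1` differs from compound 2 by 1,3-thiazol-2-yl in place of 4-hydroxyphenyl on a saturated ring carbon. Among the measured compounds shown here, only one measured step changes the group on that saturated ring carbon, from compound 1 to compound 2, and it was modest. Nothing measured points to a direction, so compound 4 is expected to stay close to compound 2. For compound 4 the estimated step is a number 2 percentage points lower from compound 2 to compound 4 (within the scatter). Compound 4 is therefore estimated at 58%, ranging from 40% to 76%.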

Compound 4, largest response reached (reported as efficacy), in percent of the reference or control that the assay uses: 62%
Beside the measured number, compound 4's estimate is 4 percentage points below it; low and high end bracket the measured number.
By their numbers in this assay, from the lowest: compounds 3, 2, 4 and 1 (each within the scatter of the next, the first and the last beyond it).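

In this assay the step from the six-membered aromatic ring of carbon only to a five-membered aromatic ring with 2 hetero atoms and 0 hydrogen-bond donors is a number 2 percentage points higher from compound 2 to compound 4 (within the scatter), so the hydroxyl group and the six-membered ring are not needed to keep this response. Against the nitrile-bearing group the step is a number 9 percentage points lower from compound 1 to compound 4 (within the scatter), which also leaves 1,3-thiazol-2-yl inseparable from 2-cyanophenyl. Nothing available explains these numbers. Open, on these data alone, is whether a non-aromatic group on that saturated ring carbon, such as a morpholine, a carboxylic acid or a primary amine, would keep the response. Also open, as far as these compounds go, is how the sulfur and nitrogen of the thiazole each contribute.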